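A few compounds are considered here, and "the series" means these few. Any claim that something is new, unique, unknown or untested is made for them only; others in the source may bear on it.

Measured so far in a functional assay on HT-29 cells (Homo sapiens) for inhibition, read by sulforhodamine B assay, with a stated time of 48 h; on this read-out higher numbers stand for weaker inhibition of growth and lower numbers for stronger inhibition of growth:
- compound 1, `CCOC(=O)C1=C(C)NC(=S)NC1c1ccc(O)c(O)c1`, gives 33.7 ug/mL
- compound 2, `CCOC(=O)C1=C(C)NC(=S)NC1c1ccc(F)cc1`, gives 26.5 ug/mL
- compound 3, `CCOC(=O)C1=C(C)NC(=O)NC1C1CCCCC1`, gives only a limit of the assay, > 250 ug/mL

Within this assay, compound 2 gives one of the two numbers; compound 1 sits within the usual scatter of it, so no order can be read between the two. The value of compound 3 is a limit and not a number, at the level described by the limit of > 250 ug/mL in this assay, at which 1 of the 3 values shown sits.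

Compound 4, `CCOC(=O)C1=C(C)NC(=S)NC1c1ccc(OC)cc1`, is not yet measured in this assay. It differs from compound 2 in one place: methoxy in place of fluoro on an aromatic carbon. Going by the values given here, no measured pair in the set shares this change, so there is no step to lean on. Among the measured compounds the aryl-bearing members with a thiocarbonyl core, compound 1 and compound 2, give numbers close to each other, which suggests the aromatic substituent has so far moved the read-out little.

On that basis the step from compound 2 to compound 4 in this assay is expected to be small, a 1.1-fold higher number from compound 2 to compound 4 (0.05 log units; within the scatter), not beyond the scatter in either direction. Compound 4 is thus estimated at 30 ug/mL, with a range from 12 ug/mL to 80 ug/mL.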

Compound 4, concentration for 50% growth inhibition: 30.6 ug/mL
The estimate for compound 4 lay 1.0-fold (0.01 log units) below the measured number, and the stated range covers the measured number.
By their numbers in this assay, from the lowest: compounds 2, 4 and 1 (each within the scatter of the next). At a limit, above all of these: compound 3.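

In this assay, the only single-place step shown falls on an aromatic carbon para to a large group, where methoxy in place of fluoro gives a 1.2-fold higher number from compound 2 to compound 4 (0.06 log units; within the scatter). Fluoro and methoxy differ in their heavy atoms and hydrogen-bond acceptors, yet no order can be read between compound 2 and compound 4, so at this position the read-out does not separate these two groups. Nothing at hand gives a cause for this step.

As far as these compounds go, whether an amine, a carboxylic acid or a longer alkoxy chain at this position would also stay within the scatter of compound 2 remains open. A single step also says nothing about a change elsewhere on the shared core.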